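Swapping the aminophenyl ketone end for a dimethoxyphenyl

This account rests on a few compounds, and the source may have more. Where it says the series, first, only, none or still open, it means among the compounds named here.

Measured so far:
compound 1, `COc1cc(-c2cc(/C=C/C(=O)c3ccc(N)cc3)[nH]n2)cc(OC)c1OC`, 91%
compound 2, `COc1ccc(-c2cc(/C=C/C(=O)c3ccc(N)cc3)[nH]n2)cc1OC`, 92%
compound 3, `COc1ccc(-c2cc(/C=C/C(=O)c3cc(OC)c(OC)c(OC)c3)[nH]n2)cc1OC`, 88%

In a functional assay on UO-31 cells (Homo sapiens) for cytotoxicity, read by sulforhodamine B assay, with a stated time of 48 h, tested at 0.01 uM (on this read-out lower numbers stand for a stronger effect and higher numbers for a weaker effect at the one concentration tested), compound 1 gives 91%. Its number sits with those of compound 2 and compound 3, each within the usual scatter, so the three measured compounds cannot be told apart on this read-out.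

Compound 4, `COc1ccc(C(=O)/C=C/c2cc(-c3cc(OC)c(OC)c(OC)c3)n[nH]2)cc1OC`, differs from compound 1 in one place: 3,4-dimethoxyphenyl in place of 4-aminophenyl on a carbonyl carbon. For the measured compounds named here, no measured step matches this change. Going by the values given here, the one measured step, a number 1 percentage points higher from compound 1 to compound 2 (within the scatter), concerns a different position and lies within the scatter. Compound 3 carries a trimethoxyphenyl on the same carbonyl carbon and gives 88%, a number within the scatter of compound 1.

For compound 4 no movement beyond the scatter is therefore expected, a step of a number 2 percentage points lower from compound 1 to compound 4 (within the scatter). Compound 4 is estimated at 89%, between 78% and 98%.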

Compound 4, a percentage reported as activity, at one concentration (the size of the read-out at that concentration, not a potency): 86%
Estimate against measurement, compound 4: 3 percentage points above; low and high end bracket the measured number.
By their numbers in this assay, from the lowest: compounds 4, 3, 1 and 2 (each within the scatter of the next).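

In this assay, replacing the group on the carbonyl carbon gives a number 5 percentage points lower from compound 1 to compound 4 (within the scatter). So 4-aminophenyl, with its hydrogen-bond donor, can give way at this position to 3,4-dimethoxyphenyl, with more heavy atoms and no such donor, without a change that can be told from scatter. No separate measurement helps to interpret this result.

As far as these compounds go, whether a carboxylic acid or a simple methyl group on this carbonyl carbon would move the number beyond the scatter remains open. So does whether a higher concentration would separate these compounds.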